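Dropping the Chloro Group from Compound 2

The source may hold more compounds than are shown below. What is called first, only, known or untested is meant among the compounds shown, and "the series" means these compounds.

Compound 1 `O=C(Nc1ccccc1)c1cc(Br)cc(Br)c1O` is a weak inhibitor: in an assay for inhibition of HSP60/HSP10 (Homo sapiens), with a stated time of 60 min (a higher number here means a weaker inhibitor, a lower number a stronger inhibitor), compound 1 gives 63000 nM. Compound 2 `O=C(Nc1cccc(Cl)c1)c1cccc(Br)c1O` differs from it in its halogens. In this assay compound 2 reaches only > 100000 nM, which is a limit of the measurement and not a number (the limit of > 100000 nM in this assay, at which 1 of the 2 values shown sits). Compound 3 `O=C(Nc1ccccc1)c1cccc(Br)c1O` differs from compound 2 by hydrogen in place of chloro on an aromatic carbon. Among the compounds with values here, no measured pair shows the effect of this change, so the expected step of a number no higher from compound 2 to compound 3 (the limit leaves the size open) is none beyond the scatter. Compound 3 is therefore expected to give about 100000 nM in this assay, somewhere between 40000 nM and 300000 nM, quite possibly again only as a limit.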

Compound 3, half-maximal inhibitory concentration: > 100000 nM
Compound 3: no number, only a limit; the forecaster's own chance of this, stated with the estimate: 60%; the middle value sits exactly at the limit.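

With chloro replaced by hydrogen, the step cannot be read, as compound 2 and compound 3 each give only a limit and no number: the limit of > 100000 nM in this assay, at which 2 of the 3 values shown sit.

Compound 3 does open one readable comparison, the loss of a bromo group from the core of compound 1: in this assay there is an at least 1.5-fold higher number from compound 1 to compound 3 (0.20 log units; that floor lies within the scatter). On these data alone, this shows that removing that bromo does not strengthen the inhibitor, though its true size stays unknown.

As far as these compounds go, what an amine or a carboxylic acid on the aromatic carbon that held the chloro would do remains open.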